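Swapping an Amino Group for Sulfanyl on a Shared Core

This account rests on a few compounds, and the source may have more. Where it says the series, first, only, none or still open, it means among the compounds named here.

Among the measured compounds shown here, compound 1 `CS(=O)(=O)N1CC(CCl)c2ccc(N)cc21` gives 13000 nM in a functional assay on UV4 cells (Cricetulus griseus) for cytotoxicity, with a stated time of 4 h (on this read-out higher numbers stand for weaker inhibition and lower numbers for stronger inhibition), the lowest of the two numbers so far, though the gap to its neighbour lies within the scatter. Compound 2 `CN(C)c1ccc2c(c1)N(S(C)(=O)=O)CC2CCl` gives 15000 nM in this assay, and the step of a 1.2-fold higher number from compound 1 to compound 2 (0.06 log units; within the scatter) altered the same aromatic carbon. Compound 3 `CS(=O)(=O)N1CC(CCl)c2ccc(S)cc21` differs from compound 1 by sulfanyl in place of amino on an aromatic carbon. For the measured compounds named here, no measured step exchanges amino for sulfanyl, so the change has no direct guide; the one step at this aromatic carbon stayed within the scatter. Therefore no step beyond the scatter is expected: no change at the digits printed from compound 1 to compound 3 (within the scatter). Compound 3 is estimated at 13000 nM, with a range from 5000 nM to 35000 nM.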

Compound 3, half-maximal inhibitory concentration: 124000 nM
The estimate for compound 3 lay 9.5-fold (0.98 log units) below the measured number; the whole stated range lies below it.
By their numbers in this assay, from the lowest: compounds 1 and 2 (each within the scatter of the next); then compound 3.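

This aromatic carbon does respond to a change of group: this assay shows a 9.5-fold higher number from compound 1 to compound 3 (0.98 log units; beyond the scatter) and an 8.3-fold higher number from compound 2 to compound 3 (0.92 log units; beyond the scatter), so inhibition is weaker with sulfanyl than with either nitrogen group. Amino and dimethylamino had stayed within the scatter of each other, so the earlier pair gave no sign of this. Sulfanyl and amino match in the counts of heavy atoms, hydrogen-bond donors and acceptors, yet the numbers still part, and no data here explain that gap.

On these data alone, whether a hydroxyl or a methoxy group on this carbon would behave like the amino groups or like sulfanyl remains open. So does the result for a methylsulfanyl group, which would show what capping the sulfur does.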